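The source may report more compounds than this note shows. Statements on the series, on what has been measured and on what is new or still open speak of the compounds shown alone.

In a functional assay on MCF7 cells (Homo sapiens) for antiproliferative activity, read by MTT assay, with a stated time of 24 h, tested at 12.5 uM (on this read-out lower numbers stand for a stronger effect and higher numbers for a weaker effect at the one concentration tested), the two measured compounds give:

Compound 1, `OC(CCn1nc2c(Br)c(Br)c(Br)c(Br)c2n1)c1cccc(Br)c1`: 81%
Compound 2, `CC(O)CCn1nc2c(Br)c(Br)c(Br)c(Br)c2n1`: 99%

Compound 2 stands highest of these two numbers, meaning the weaker effect; its nearest neighbour is compound 1, and the step of a number 18 percentage points higher from compound 1 to compound 2 (beyond the scatter) lies beyond the scatter. Compound 3, `OC(CCn1nc2c(Br)c(Br)c(Br)c(Br)c2n1)c1ccc(Cl)cc1`, is not yet measured. It differs from compound 2 in one place: 4-chlorophenyl in place of methyl on a saturated chain carbon bound to an oxygen on a saturated carbon and a saturated chain carbon. Going by the values given here, the only measured step that bears on this change runs the other way, a methyl standing in for a ring, and it gave a number 18 percentage points higher from compound 1 to compound 2 (beyond the scatter). Among the compounds with values here, putting a ring back in place of the methyl is therefore expected to lower the number in this assay by a similar amount, although 4-chlorophenyl is not the same ring as 3-bromophenyl and only one such step is known. Compound 3 is expected to give about 83% in this assay, between 68% and 98%, which means an expected step of a number 16 percentage points lower from compound 2 to compound 3 (beyond the scatter).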

Compound 3, a percentage reported as activity, at one concentration (the size of the read-out at that concentration, not a potency): 90%
For compound 3 the middle estimate is 7 percentage points below the measured one, and the stated range covers the measured number.
By their numbers in this assay, from the lowest: compounds 1, 3 and 2 (each within the scatter of the next, the first and the last beyond it).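

In this assay, replacing methyl with 4-chlorophenyl on the chain carbon bound to the oxygen gives a number 9 percentage points lower from compound 2 to compound 3 (within the scatter). This change therefore does not repeat the clear separation seen with 3-bromophenyl, where the step was a number 18 percentage points higher from compound 1 to compound 2 (beyond the scatter). The two rings cannot be told apart either, with a number 9 percentage points higher from compound 1 to compound 3 (within the scatter), so compound 3 lies within the scatter of both compounds and a ring at this position cannot be said to matter in general.

No available data bear on the reason for these steps. As far as these compounds go, it remains open whether 4-bromophenyl, which would separate the choice of halogen from its place on the ring, or an amine or a carboxylic acid on this carbon would give a step beyond the scatter.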